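A few compounds are considered here, and "the series" means these few. Any claim that something is new, unique, unknown or untested is made for them only; others in the source may bear on it.

In an ADME assay on MRC5 cells (Homo sapiens) for inhibition, with a stated time of 72 h (a higher number here means that more compound is needed for the effect, a lower number that less compound is needed), compound 1 `CCc1ccccc1C(=O)Nc1c[nH]nc1C(=O)N[C@H]1CC[C@H](OC)CC1` gives 3400 nM and compound 3 `CO[C@H]1CC[C@H](NC(=O)c2n[nH]cc2NC(=O)c2cc(Cl)cc(Cl)c2)CC1` gives 13000 nM. Compound 2 `COc1cccc(OC)c1C(=O)Nc1c[nH]nc1C(=O)NC1CC1` gives only a limit, > 50000 nM, and no number. Compound 4 `COc1cccc(OC)c1C(=O)Nc1c[nH]nc1C(=O)NCc1ccccn1` differs from compound 2 in one group: (pyridin-2-yl)methyl in place of cyclopropyl on an amide-type nitrogen. In short, (pyridin-2-yl)methyl stands in place of cyclopropyl on an amide-type nitrogen. Among the compounds with values here, the only measured step, a 3.8-fold higher number from compound 1 to compound 3 (0.58 log units; beyond the scatter), is modest and concerns a group on a carbonyl carbon, so it bears only indirectly on this change. Within the data shown here, no measured step covers the amide-type nitrogen, so no shift beyond the scatter is expected. The expected step is an at least 1.1-fold lower number from compound 2 to compound 4 (0.04 log units; that floor lies within the scatter). For compound 4 the estimated value is 45000 nM, with an expected range from 17000 nM to 80000 nM.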

Compound 4, half-maximal effective concentration: > 50000 nM
Compound 4 gave a limit, no number; the forecaster's own chance of this, stated with the estimate: 65%; middle value at least 1.1-fold (0.04 log units) away from the limit.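

Compound 2 and compound 4 each give only a limit, not a number, so no step between them can be read: the limit of > 50000 nM in this assay, at which 2 of the 4 values shown sit.

The compounds shown leave open whether (pyridin-2-yl)methyl in place of cyclopropyl on an amide-type nitrogen changes the number at all.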